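This account rests on a few compounds, and the source may have more. Where it says the series, first, only, none or still open, it means among the compounds named here.

Measured so far in an ADME assay on HaCaT cells (Homo sapiens) for inhibition, read by sulforhodamine B assay, with a stated time of 48 h; a lower number here means a stronger inhibitor of growth, a higher number a weaker inhibitor of growth:
- Compound 1 `CCOC(=O)c1nn(-c2ccccc2)c(-c2ccc([N+](=O)[O-])cc2)c1CNC(C)(C)C`: 103000 nM; 130000 nM (2 entries)
- Compound 2 `CC(C)(C)NCc1c(C(=O)O)nn(-c2ccccc2)c1-c1ccc(Br)cc1`: 366000 nM
- Compound 3 `CC(C)(C)NCc1c(C(=O)O)nn(-c2ccccc2)c1-c1ccccc1`: > 716000 nM (a limit)

Compound 3 gives > 716000 nM, which is a limit of the assay and not a number. Its true place in this assay is therefore unknown.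

The next compound, compound 4 `CC(C)(C)NCc1c(C(=O)O)nn(-c2ccccc2)c1-c1ccc([N+](=O)[O-])cc1`, is compound 3 with one change: nitro in place of hydrogen on an aromatic carbon. In other words, phenyl becomes 4-nitrophenyl.

Going by the values given here, the one measured step of a similar kind is an at least 1.9-fold higher number from compound 2 to compound 3 (0.29 log units; that floor lies within the scatter). Read in reverse, this step from compound 2 to compound 3 hints that a group in place of that hydrogen may lower the number, though bromo is not nitro and the evidence is thin. Compound 4 differs elsewhere from compound 1, which also carries 4-nitrophenyl and gives 103000 nM; 130000 nM (2 entries).

A modest move towards a lower number is therefore expected, and the expected step is an at least 2.0-fold lower number from compound 3 to compound 4 (0.31 log units; beyond the scatter). The estimate for compound 4 is 350000 nM, with an expected range from 130000 nM to 800000 nM.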

Compound 4, concentration for 50% growth inhibition: > 634000 nM
Compound 4: no number, only a limit; the forecaster's own chance of this, stated with the estimate: 30%; at least 1.8-fold (0.25 log units) between middle value and limit.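

In this assay compound 4 gives > 634000 nM, which is a limit of the assay. With the carboxylic acid kept, 4-nitrophenyl therefore sits at a limit just as phenyl does, so the step between compound 3 and compound 4 cannot be read, and nitro in place of that hydrogen gives no measured number here. Swapping the bromo for nitro gives an at least 1.7-fold higher number from compound 2 to compound 4 (0.23 log units; that floor lies within the scatter), so this step does not separate the two groups, and bromo remains the only group on this ring of the acids with a measured number.

From the compounds shown here alone, it remains open whether an amine or a methoxy group in place of that hydrogen would give a readable number. Also open, going by these compounds, is how such groups would behave alongside the ethyl ester of compound 1, which gives 103000 nM; 130000 nM (2 entries).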